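The compounds below may be only part of what the source reports. "The series", "measured", "known", "first", "only" and "open" are said of these compounds alone.

Measured so far in an ADME assay on microsomes from liver (Mus musculus) for metabolic stability, with a stated time of 10 min; on this read-out lower numbers stand for a less stable compound and higher numbers for a more stable compound:

- Compound 1 `C[C@]1(C(=O)O)CC[C@H](C(=O)N2CC[C@](c3ccc(C(F)(C(F)(F)F)C(F)(F)F)cc3)(S(=O)(=O)c3ccc(F)cc3)C2)CC1`: 93%
- Compound 2 `O=C(O)C12CCC(C(=O)N3CC[C@](c4ccc(C(F)(C(F)(F)F)C(F)(F)F)cc4)(S(=O)(=O)c4ccc(F)cc4)C3)(CC1)C2`: "not determined" (no result reported)

Compound 2 has no place on this scale, since its entry reads "not determined" (no result reported) and no number was reported. Among the compounds with values here, the only number available therefore belongs to compound 1, which shares its core with the other two compounds.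

Compound 3 `O=C(O)C12CCC(C(=O)N3CC[C@](c4ccc(C(F)(C(F)(F)F)C(F)(F)F)cc4)(S(=O)(=O)c4ccc(F)cc4)C3)(CC1)OC2` has not yet been measured. The structural change is a group of 11 heavy atoms (8 carbon, 3 oxygen; one six-membered non-aromatic ring of carbon only, one six-membered non-aromatic ring with 1 hetero atom) in place of a group of 10 heavy atoms (8 carbon, 2 oxygen; 2 five-membered non-aromatic rings of carbon only), on a carbonyl carbon: a group of 11 heavy atoms, including one six-membered non-aromatic ring with 1 hetero atom, replaces a group with 2 five-membered non-aromatic rings of carbon only, on a carbonyl carbon.

Within the data shown here, with no measured step to lean on, no change beyond the usual scatter is expected in this assay, and neither direction is favoured. The best guide is compound 1 at 93%, so a high reading is expected. For compound 3 the estimated value is 88%, with an expected range from 70% to 100%.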

Compound 3, percent of the compound remaining: 94%
For compound 3 the middle estimate is 6 percentage points below the measured one; low and high end bracket the measured number.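

In this assay, within the data shown here, the step is a number 1 percentage points higher from compound 1 to compound 3 (within the scatter), so the first reading for a group with a six-membered non-aromatic ring with 1 hetero atom, on a carbonyl carbon whose other neighbour is an amide-type nitrogen in a ring, matches that of compound 1 within the usual scatter. The comparison of compound 3 with compound 2 cannot be read, as compound 2 has no number. Nothing measured here gives a reason for this result.

All the compounds shown carry a carboxylic acid on this group, so how a primary amide or an alcohol in its place would read remains open. Also open, from the compounds shown here alone, is how a ring holding a nitrogen instead of the oxygen of compound 3 would read.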